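Ring-expanded amine in place of methylpiperazine

A few compounds are considered here, and "the series" means these few. Any claim that something is new, unique, unknown or untested is made for them only; others in the source may bear on it.

Measured compounds:
compound 1 `CC(O)(C#Cc1cccc(Nc2ncnc3[nH]ccc23)c1)c1nccs1`: 1640 nM
compound 2 `C[C@H]1CN(c2ccc(C#CC(C)(O)c3nccs3)cc2Nc2ncnc3[nH]ccc23)CCN1`: 69.2 nM

In an assay for inhibition of mitogen-activated protein kinase kinase kinase 14 (Homo sapiens), read by luminescence and ADP-Glo, with a stated time of 120 min, in the presence of a further agent that is not named here (a lower number here means a stronger inhibitor, a higher number a weaker inhibitor), compound 2 gives 69.2 nM, the lowest of the two numbers, and compound 1 gives 1640 nM. Going by the values given here, the only measured step, a 24-fold lower number from compound 1 to compound 2 (1.37 log units; beyond the scatter), shows that adding a saturated amine ring at this position brings a large gain. Compound 3 `CN1CCCN(c2ccc(C#CC(C)(O)c3nccs3)cc2Nc2ncnc3[nH]ccc23)CC1` keeps such a ring; it differs from compound 2 by 4-methyl-1,4-diazepan-1-yl in place of 3-methylpiperazin-1-yl on an aromatic carbon. Among the compounds with values here, no measured step separates these two amine rings, so the expected shift in this assay is modest: a 1.6-fold higher number from compound 2 to compound 3 (0.20 log units; within the scatter), a slight loss within or near the scatter. Compound 3 is estimated at 110 nM, with a range of 35 nM to 350 nM.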

Compound 3, half-maximal inhibitory concentration: 60.1 nM
Compound 3: middle estimate off by 1.8-fold (0.26 log units), on the high side; the range from low to high includes it.
By their numbers in this assay, from the lowest: compounds 3 and 2 (each within the scatter of the next); then compound 1.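

In this assay, the 4-methyl-1,4-diazepan-1-yl and 3-methylpiperazin-1-yl rings cannot be told apart: a 1.2-fold lower number from compound 2 to compound 3 (0.06 log units; within the scatter) holds even though the entering group has 0 hydrogen-bond donors and the leaving group has 1. The large gain over hydrogen on this aromatic carbon also appears with this second amine ring, as a 27-fold lower number from compound 1 to compound 3 (1.44 log units; beyond the scatter). No evidence bears on why the two rings give such similar numbers.

Still open, going by these compounds, is whether an open-chain amine such as dimethylamino would keep this gain. Morpholin-4-yl would test whether a second ring nitrogen is needed.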